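Trading the Carbamoylphenyl for a Thiazole: Solubility Outlook

A few compounds are considered here, and "the series" means these few. Any claim that something is new, unique, unknown or untested is made for them only; others in the source may bear on it.

Of the compounds shown here, three built on one shared core have been measured in a physicochemical assay for solubility, at pH 6; on this read-out higher numbers stand for higher solubility and lower numbers for lower solubility. Compound 1 `N#Cc1ccc(-c2cc(-c3ccc(C(N)=O)cc3)cc(-c3ccco3)n2)cc1` gives 10000 nM. Compound 2 `NC(=O)c1ccc(-c2cc(-c3ccc(-c4nccs4)cc3)nc(-c3ccco3)c2)cc1` gives 125000 nM, and compound 3 `NC(=O)c1ccc(-c2cc(-c3ccc(-c4cnco4)cc3)nc(-c3ccco3)c2)cc1` gives 15000 nM. Compound 2 stands highest of the three numbers: the change to it is a 13-fold higher number from compound 1 to compound 2 (1.10 log units; beyond the scatter), while the change away from it is an 8.3-fold lower number from compound 2 to compound 3 (0.92 log units; beyond the scatter), so both neighbours sit beyond the scatter below it.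

Compound 4 `c1coc(-c2cc(-c3nccs3)cc(-c3ccc(-c4nccs4)cc3)n2)c1` has not yet been measured. It differs from compound 2 in one place: 1,3-thiazol-2-yl in place of 4-carbamoylphenyl on an aromatic carbon. The new group sits on the core opposite the ring nitrogen, and the 4-carbamoylphenyl that every measured compound carried is gone.

Neither measured step covers this exchange. Both of them, a 13-fold higher number from compound 1 to compound 2 (1.10 log units; beyond the scatter) and an 8.3-fold lower number from compound 2 to compound 3 (0.92 log units; beyond the scatter), swapped the small group at the far end of the molecule, and the 4-carbamoylphenyl stayed put throughout. The entering 1,3-thiazol-2-yl did appear once, in the step from compound 1 to compound 2, but there it replaced cyano, not a nine-atom arm, so that step does not transfer. For the measured compounds named here, with no direct precedent, the step of a 4.2-fold lower number from compound 2 to compound 4 (0.62 log units; beyond the scatter) is expected to be a modest fall, with wide uncertainty. Compound 4 is therefore estimated at 30000 nM, within 5000 nM to 125000 nM.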

Compound 4, solubility: < 1000 nM
Compound 4 gave a limit, no number; the forecaster's own chance of this, stated with the estimate: 5%; at least 30-fold (1.47 log units) between middle value and limit.
By their numbers in this assay, from the lowest: compounds 1 and 3 (each within the scatter of the next); then compound 2. At a limit, below all of these: compound 4.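

For the compounds shown here, every earlier compound kept its 4-carbamoylphenyl, so this is the first view of how a change opposite the ring nitrogen reads in this assay. Going by these compounds alone, putting 1,3-thiazol-2-yl in place of 4-carbamoylphenyl there gives an at least 120-fold lower number from compound 2 to compound 4 (2.09 log units; beyond the scatter), a larger step than either of those printed among the earlier compounds, so this position is not indifferent to the group it carries. Compound 4 gives < 1000 nM, which is a limit and not a number, so the step marks only a minimum and its full size stays unread: the limit of < 1000 nM in this assay, at which 1 of the 4 values shown sits.

The compounds shown do not separate what the departure of 4-carbamoylphenyl contributes from what the arrival of 1,3-thiazol-2-yl contributes, as both happen in a single exchange. Also open, going by these compounds, is whether a different group at this position, such as a simple amine, a carboxylic acid or a short chain ending in either, would keep the reading closer to that of compound 2 at 125000 nM. Such a group might instead give a limit, as compound 4 does.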